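The source may report more compounds than this note shows. Statements on the series, on what has been measured and on what is new or still open speak of the compounds shown alone.

In a functional assay on MCF7 cells (Homo sapiens) for inhibition, read by spectrophotometry and sulforhodamine B assay, with a stated time of 48 h (a higher number here means a weaker inhibitor of growth, a lower number a stronger inhibitor of growth), compound 1 (`Cc1ccc(N2C(=O)CS/C2=N/N=C/c2c[nH]c3ccc(Br)cc23)cc1`) gives 59500 nM and compound 2 (`O=C1CS/C(=N/N=C/c2c[nH]c3ccccc23)N1c1cccc2ccccc12`) gives 34900 nM, so these two values lie within the scatter of each other. Compound 2 stands well above compound 3 (`Cc1ccc(NC(=S)N/N=C/c2c[nH]c3ccccc23)cc1`), which gives 2520 nM, a gap beyond the scatter. Compound 4 (`O=C1CS/C(=N/N=C/c2c[nH]c3ccc(Br)cc23)N1c1cccc2ccccc12`) is compound 2 changed in one place: bromo in place of hydrogen on an aromatic carbon. Going by the values given here, no measured pair isolates this change, so the evidence is indirect. Compound 1 also carries a bromo, and at 59500 nM it sits within the scatter of compound 2, so no step beyond the scatter is expected in either direction. The estimated change is a 1.0-fold higher number from compound 2 to compound 4 (0.00 log units; within the scatter). For compound 4 the expected value is 35000 nM, with an estimated range from 14000 nM to 85000 nM.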

Compound 4, concentration for 50% growth inhibition: 6060 nM
Compound 4: middle estimate off by 5.8-fold (0.76 log units), on the high side; measured number outside the range, below it.
By their numbers in this assay, from the lowest: compound 3; then compound 4; then compounds 2 and 1 (each within the scatter of the next).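

In this assay, going by these compounds alone, bromo in place of hydrogen on this aromatic carbon, meta to a fused ring and para to a fused ring, gives a 5.8-fold lower number from compound 2 to compound 4 (0.76 log units; beyond the scatter) and this is the only step here between compounds that differ in one place. It shows that this position is not indifferent to substitution: one added bromine atom moves the number beyond the scatter, towards stronger growth inhibition. No measurement here accounts for the size of this step.
From the compounds shown here alone, whether other groups at this position, such as chloro, methoxy or an amine, would have a similar effect remains open. So does whether bromo has the same effect on other compounds of this kind.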